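Swapping the urea aryl group: fluorine out, chlorine in

The compounds below may be only part of what the source reports. "The series", "measured", "known", "first", "only" and "open" are said of these compounds alone.

Measured compounds, with their result in a functional assay on MKN-45 cells (Homo sapiens) for cytotoxicity, read by MTT assay, with a stated time of 72 h; a higher number here means a weaker inhibitor, a lower number a stronger inhibitor:
Compound 1 `CN(C)CCCNc1nc(-c2ccc(NC(=O)Nc3ccc(Cl)cc3Cl)cc2)nc2c(Cl)c(Cl)sc12` gives 2560 nM.
Compound 2 `CN(C)CCNc1nc(-c2ccc(NC(=O)Nc3ccc(F)cc3)cc2)nc2ccsc12` gives 330 nM.
Compound 3 `Cc1ccc(NC(=O)Nc2ccc(-c3nc(NCCCN(C)C)c4sc(Cl)c(Cl)c4n3)cc2)cc1` gives 3700 nM.

Compound 2 has the lowest number of the three in this assay, and its gaps to compound 1 and to compound 3 both lie beyond the scatter. Compound 2 differs from those two in several places at once, so its lead cannot be tied to any single feature.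

Compound 4 `CN(C)CCNc1nc(-c2ccc(NC(=O)Nc3ccccc3Cl)cc2)nc2ccsc12` keeps everything in compound 2 except one group: 2-chlorophenyl in place of 4-fluorophenyl on an amide-type nitrogen. Among the measured compounds shown here, the only measured step at this same position is a 1.4-fold higher number from compound 1 to compound 3 (0.16 log units; within the scatter), which shows that exchanging one aryl group for another on the urea nitrogen left the number essentially unchanged, although on a different core. On that basis, no step beyond the scatter is expected from compound 2 to compound 4, and the expected step of a 1.4-fold higher number from compound 2 to compound 4 (0.13 log units; within the scatter) is small.

Compound 4 is therefore estimated at 450 nM in this assay, with a likely range from 150 nM to 1400 nM.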

Compound 4, half-maximal inhibitory concentration: 850 nM
Beside the measured number, compound 4's estimate is 1.9-fold (0.28 log units) below it; low and high end bracket the measured number.
By their numbers in this assay, from the lowest: compound 2; then compound 4; then compounds 1 and 3 (each within the scatter of the next).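

The aryl group on the urea nitrogen is not interchangeable on the core of compound 2: in this assay, 2-chlorophenyl in place of 4-fluorophenyl gives a 2.6-fold higher number from compound 2 to compound 4 (0.41 log units; beyond the scatter). This modest step lies beyond the scatter, whereas the earlier aryl exchange on a different core, a 1.4-fold higher number from compound 1 to compound 3 (0.16 log units; within the scatter), stayed within it, so that earlier step does not carry over to every core. No measurement available here explains the rise in the number.

The change swaps the halogen and its place on the ring together, so the compounds shown cannot separate the two; 4-chlorophenyl or 2-fluorophenyl on the same nitrogen would do so. Also open, going by these compounds, is how a group without halogen, such as 4-methoxyphenyl, would fare on the core of compound 2.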